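Extending compound 2 on the saturated ring carbon

The source may report more compounds than this note shows. Statements on the series, on what has been measured and on what is new or still open speak of the compounds shown alone.

Measured so far:
compound 1 `Cc1cc(C)c(S(=O)(=O)N2CCC(N3CCC(Cc4ccccc4)CC3)CC2)c(C)c1` — 3.5 nM
compound 2 `Cc1cc(C)c(S(=O)(=O)N2CCC(N3CCCCC3)CC2)c(C)c1` — 2200 nM

In a functional assay on DLD-1 cells (Homo sapiens) for antiproliferative activity, read by CellTiter-Glo, with a stated time of 72 h (a lower number here means a stronger inhibitor, a higher number a weaker inhibitor), compound 2 gives the higher of the two numbers shown, with compound 1 the only neighbour, so far below it. Compound 3 `C#CCCC(=O)CC1CCN(C2CCN(S(=O)(=O)c3c(C)cc(C)cc3C)CC2)CC1` arises from compound 2 by this change: ((but-3-yn-1-yl)carbonyl)methyl in place of hydrogen on a saturated ring carbon. Among the measured compounds shown here, the one step that bears on it is a 630-fold higher number from compound 1 to compound 2 (2.80 log units; beyond the scatter), a large loss when a group on that same ring carbon was taken away. Restoring a group of comparable size is therefore expected to bring the number down again, though not necessarily as far. Compound 3 is estimated at 120 nM, between 15 nM and 900 nM, a step of an 18-fold lower number from compound 2 to compound 3 (1.26 log units; beyond the scatter).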

Compound 3, half-maximal inhibitory concentration: 3 nM
Beside the measured number, compound 3's estimate is 40-fold (1.60 log units) above it; the whole stated range lies above it.
By their numbers in this assay, from the lowest: compounds 3 and 1 (each within the scatter of the next); then compound 2.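

In this assay the saturated ring carbon takes ((but-3-yn-1-yl)carbonyl)methyl with a 730-fold lower number from compound 2 to compound 3 (2.87 log units; beyond the scatter) and so does not need a benzyl group to give a low number. With a 1.2-fold lower number from compound 1 to compound 3 (0.07 log units; within the scatter) as the step between the two substituents, a chain with no ring serves as well as benzyl at this position. Nothing available explains why two such different groups give matching numbers.

The compounds shown leave open how a shorter chain on this ring carbon would read, and whether an amine or a carboxylic acid at the chain end would keep the number low.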